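Trading 3,4-dichlorophenyl for 4-chlorobenzyl: an expected loss

This account rests on a few compounds, and the source may have more. Where it says the series, first, only, none or still open, it means among the compounds named here.

In a functional assay on MDA-MB-231 cells (Homo sapiens) for inhibition, read by MTT assay, with a stated time of 48 h (a higher number here means a weaker inhibitor of growth, a lower number a stronger inhibitor of growth), compound 1 `FC(F)(F)c1cc(NC(=S)Nc2ccc3ncnc(Nc4cccc(Br)c4)c3c2)ccc1Cl` gives 1100 nM. Compound 2 `S=C(Nc1ccc(Br)cc1)Nc1ccc2ncnc(Nc3cccc(Br)c3)c2c1` is reported only as a limit of the assay, > 30000 nM. Compound 3 `S=C(Nc1ccc(Cl)c(Cl)c1)Nc1ccc2ncnc(Nc3cccc(Br)c3)c2c1` gives 4800 nM, the higher of the two actual numbers in this set, and compound 1 is its nearest neighbour.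

The next change leads to compound 4 `S=C(NCc1ccc(Cl)cc1)Nc1ccc2ncnc(Nc3cccc(Br)c3)c2c1`, with 4-chlorobenzyl in place of 3,4-dichlorophenyl on an amide-type nitrogen. Going by the values given here, no measured step makes this exact change, but three steps at the same nitrogen offer guidance. The most relevant is an at least 6.2-fold lower number from compound 2 to compound 3 (0.79 log units; beyond the scatter), where 3,4-dichlorophenyl replaces 4-bromophenyl. The others are a 4.4-fold higher number from compound 1 to compound 3 (0.64 log units; beyond the scatter), where chloro replaces trifluoromethyl, and an at least 27-fold higher number from compound 1 to compound 2 (1.43 log units; beyond the scatter). Across these three compounds, the group with a single halogen, in compound 2, gives the weakest result, and compound 4 also carries a single halogen on its ring. That parallel is imperfect, since compound 4 is a benzyl rather than a phenyl case, so a modest move towards weaker growth inhibition in this assay is expected rather than a collapse as complete as in compound 2. The expected step is a 2.5-fold higher number from compound 3 to compound 4 (0.40 log units; beyond the scatter). For compound 4 the estimate is 12000 nM, with an expected range of 4000 nM to 30000 nM.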

Compound 4, concentration for 50% growth inhibition: 23000 nM
Compound 4: the middle estimate sits 1.9-fold (0.28 log units) below what was measured, within the range that was stated.
By their numbers in this assay, from the lowest: compound 1; then compound 3; then compound 4. At a limit, above all of these: compound 2.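

In this assay, compound 4 is the only benzyl case among the compounds shown, and it adds to the earlier phenyl series at this amide-type nitrogen. The change from 3,4-dichlorophenyl to 4-chlorobenzyl gives a 4.8-fold higher number from compound 3 to compound 4 (0.68 log units; beyond the scatter), while the change from 4-chloro-3-(trifluoromethyl)phenyl to 4-chlorobenzyl gives a 21-fold higher number from compound 1 to compound 4 (1.32 log units; beyond the scatter), so in these two pairs the benzyl compound is clearly the weaker inhibitor of growth. The comparison with the 4-bromophenyl case is less firm, reading an at least 1.3-fold lower number from compound 2 to compound 4 (0.11 log units; that floor lies within the scatter), which sets no order between those two compounds, since compound 2 has a limit of the assay and not a number: the limit of > 30000 nM in this assay, at which 1 of the 4 values shown sits.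

These compounds leave open whether the higher number of compound 4 goes with the added carbon of the benzyl group or with the loss of the second ring substituent, and a 3,4-dichlorobenzyl or a 4-chlorophenyl group at this nitrogen would separate the two. From the compounds shown here alone, it also remains open how a longer chain, such as 2-(4-chlorophenyl)ethyl, would read out in this assay.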